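A few compounds are considered here, and "the series" means these few. Any claim that something is new, unique, unknown or untested is made for them only; others in the source may bear on it.

Measured so far in a functional assay on A549 cells (Homo sapiens) for cytotoxicity, read by MTT assay, with a stated time of 72 h; on this read-out higher numbers stand for weaker inhibition and lower numbers for stronger inhibition:
- compound 1 `CN(C)CCn1cnnc1-c1cc(Oc2ccc(NC(=O)N/N=C/c3ccc(O)c(F)c3)cc2F)ccn1` — 13400 nM
- compound 2 `CN(C)CCn1cnnc1-c1cc(Oc2ccc(NC(=O)N/N=C/c3ccc(O)c(O)c3)cc2F)ccn1` — limit of the assay, > 100000 nM
- compound 3 `CN(C)CCn1cnnc1-c1cc(Oc2ccc(NC(=O)N/N=C/c3ccc(O)cc3)cc2F)ccn1` — 3560 nM

Compound 3 gives the lowest number among the two numbers shown; compound 1 sits above it by a 3.8-fold lower number from compound 1 to compound 3 (0.58 log units; beyond the scatter). Compound 2 sits at the assay limit, (the limit of > 100000 nM in this assay, at which 1 of the 3 values shown sits). Relative to that limit compound 3 stands lower by an at least 28-fold lower number from compound 2 to compound 3 (1.44 log units; beyond the scatter).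

Compound 4 `COc1ccc(/C=N/NC(=O)Nc2ccc(Oc3ccnc(-c4nncn4CCN(C)C)c3)c(F)c2)cc1O` differs from compound 3 by 3-hydroxy-4-methoxyphenyl in place of 4-hydroxyphenyl on a carbon with a double bond to nitrogen. The two measured steps both concern the same phenyl ring: adding fluoro to it costs a 3.8-fold lower number from compound 1 to compound 3 (0.58 log units; beyond the scatter) in reverse, and adding hydroxy costs an at least 28-fold lower number from compound 2 to compound 3 (1.44 log units; beyond the scatter) in reverse, both beyond the scatter. Compound 4 again carries a second substituent on that ring, a hydroxy, while the hydroxy of compound 3 becomes methoxy; so a higher number is expected, between the fluoro case and the dihydroxy case. For compound 4 the expected step is an 8.4-fold higher number from compound 3 to compound 4 (0.93 log units; beyond the scatter). Compound 4 is estimated at 30000 nM, within 8000 nM to 100000 nM.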

Compound 4, half-maximal inhibitory concentration: > 100000 nM
Compound 4 was reported as a limit (the forecaster's own chance of this, stated with the estimate: 25%); at least 3.3-fold (0.52 log units) between middle value and limit.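

In this assay, 3-hydroxy-4-methoxyphenyl in place of 4-hydroxyphenyl gives an at least 28-fold higher number from compound 3 to compound 4 (1.44 log units; beyond the scatter), and in place of 3-fluoro-4-hydroxyphenyl it gives an at least 7.4-fold higher number from compound 1 to compound 4 (0.87 log units; beyond the scatter). Among the compounds shown, both rings with two oxygen substituents leave the readable range, so turning one hydroxy into methoxy in compound 4 gives no readable value, whereas the fluoro ring of compound 1 keeps one. Compound 2 and compound 4 both stand as limits of the assay, so the step between them cannot be read: the limit of > 100000 nM in this assay, at which 2 of the 4 values shown sit.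

Going by these compounds, how 4-methoxyphenyl alone would read remains open, which leaves the effect of methoxy apart from the second substituent unresolved. Also open, on these data alone, is whether an amine or a carboxylic acid as the second substituent on this ring would keep a readable value, as fluoro does.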